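Swapping tert-butyl for acetyl on a phenylurea

The source may report more compounds than this note shows. Statements on the series, on what has been measured and on what is new or still open speak of the compounds shown alone.

Three ureas have been measured in an ADME assay on the whole organism with Oryza sativa as the target, tested at 10 uM; a higher number here means a weaker effect of the compound at the concentration tested, a lower number a stronger effect. Compound 1 `C[C@H](NC(=O)Nc1ccccc1C(C)(C)C)c1ccccc1` gives 100%. Compound 2 `C[C@@H](NC(=O)Nc1ccc(C(C)(C)C)cc1)c1ccccc1` gives 53%, and compound 3 `C[C@H](NC(=O)Nc1ccc(C(C)(C)C)cc1)c1ccccc1` gives 64%. Compound 2 therefore has the lowest of the three numbers, which in this assay means the strongest effect at the concentration tested; compound 3 lies nearest to it, and compound 1 lies furthest away.

Within the data shown here, the one step between two measured compounds that differ in a single place is a number 11 percentage points higher from compound 2 to compound 3 (beyond the scatter). That step rests on the fact that compounds 2 and 3 differ only in the configuration as drawn: the two compounds share every atom and bond and differ only in the drawn configuration at one saturated chain carbon.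

Compound 4 `CC(=O)c1ccc(NC(=O)N[C@H](C)c2ccccc2)cc1` has not yet been measured. It differs from compound 2 in one place: acetyl in place of tert-butyl on an aromatic carbon

Among the measured compounds shown here, no measured step exchanges one group for another on the aromatic ring, so the single measured step, which concerns configuration alone, says little about this change. On these data alone, the expectation therefore rests on the spread of the three measured numbers rather than on a precedent, and the direction remains open. Compound 4 is estimated to give 70%, with a range from 40% to 100%. That estimate means an expected step of a number 17 percentage points higher from compound 2 to compound 4 (beyond the scatter), a move toward the middle of the measured spread.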

Compound 4, a percentage reported as activity, at one concentration (the size of the read-out at that concentration, not a potency): 84%
Estimate against measurement, compound 4: 14 percentage points below; the measured number falls inside the stated range.
By their numbers in this assay, from the lowest: compound 2; then compound 3; then compound 4; then compound 1.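

In this assay the exchange of tert-butyl for acetyl on this aromatic carbon, para to a large group, gives a number 31 percentage points higher from compound 2 to compound 4 (beyond the scatter) and so a weaker effect at the concentration tested. Among these compounds, this is the first measured sign that the group at this place on the ring matters, and the step counts as large, whereas the only earlier step, a change of configuration alone, counts as modest. The exchange replaces an all-carbon group with one that holds an oxygen and a hydrogen-bond acceptor, but nothing at hand shows which feature of the two groups, if any, accounts for the step.

On these data alone, one exchange gives a single pair of groups and no trend, so it remains open where other groups on this carbon, such as a carboxylic acid, an amine or a longer chain, would fall relative to compound 2 and compound 4. Also open, as far as these compounds go, is whether the same exchange made on compound 3, with the other drawn configuration, would give a step of similar size.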